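Moving the Chlorine and Trifluoromethyl Around the Urea Ring

The source may report more compounds than this note shows. Statements on the series, on what has been measured and on what is new or still open speak of the compounds shown alone.

Four compounds are compared here, all built around a urea linking two aromatic rings, with an amide arm ending in a phenylethyl group. Compound 1 `CC(NC(=O)C#Cc1ccc(NC(=O)Nc2cc(C(F)(F)F)ccc2Cl)cc1)c1ccccc1` and compound 2 `CC(NC(=O)C#Cc1ccc(NC(=O)Nc2ccc(Cl)c(C(F)(F)F)c2)cc1)c1ccccc1` share one core, while compound 3 `CC(NC(=O)c1ccc(-c2ccc(NC(=O)Nc3cc(C(F)(F)F)ccc3Cl)cc2)cc1)c1ccccc1` and compound 4 `CC(NC(=O)c1ccc(-c2ccc(NC(=O)Nc3ccc(Cl)c(C(F)(F)F)c3)cc2)cc1)c1ccccc1` share another. The difference between the two cores is not broken down here.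

In a functional assay on A-375 cells (Homo sapiens) for inhibition, read by MTT assay, with a stated time of 120 h (a higher number here means a weaker inhibitor, a lower number a stronger inhibitor), compound 1 gives 30500 nM. In this assay compound 2 gives 16800 nM, and compound 3 gives 16900 nM. Compound 4 has not yet been measured.

Within the first core, the change is 4-chloro-3-(trifluoromethyl)phenyl in place of 2-chloro-5-(trifluoromethyl)phenyl on an amide-type nitrogen. That change produced a 1.8-fold lower number from compound 1 to compound 2 (0.26 log units; within the scatter), a step too small to be read as a real difference in potency.

Within the second core, the change from compound 3 to compound 4 is 4-chloro-3-(trifluoromethyl)phenyl in place of 2-chloro-5-(trifluoromethyl)phenyl on an amide-type nitrogen. The surroundings of the exchanged group are the same in both pairs, so this is the same change made on a different core.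

Among the compounds with values here, for compound 4 the expectation is therefore a number close to that of compound 3, since the only precedent, compound 1 to compound 2, gave a 1.8-fold lower number from compound 1 to compound 2 (0.26 log units; within the scatter), which lies within the scatter. The estimated step is a 1.4-fold lower number from compound 3 to compound 4 (0.15 log units; within the scatter). Compound 4 is expected to give about 12000 nM in this assay, with a plausible range estimated from 5000 nM to 30000 nM.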

Compound 4, half-maximal inhibitory concentration: 12800 nM
Estimate against measurement, compound 4: 1.1-fold (0.03 log units) below, and the stated range covers the measured number.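

In this assay, the same exchange on the second core gives a 1.3-fold lower number from compound 3 to compound 4 (0.12 log units; within the scatter), so here too it cannot be read as a real difference in potency. Set side by side, the steps on the two cores agree, with nothing to separate them: the same change on two cores in this assay, a 1.8-fold lower number (0.26 log units; within the scatter) from compound 1 to compound 2 and a 1.3-fold lower number (0.12 log units; within the scatter) from compound 3 to compound 4, 1.4-fold (0.14 log units) apart, within the scatter of two such steps

This shows that, on these two cores, replacing 2-chloro-5-(trifluoromethyl)phenyl with 4-chloro-3-(trifluoromethyl)phenyl leaves the number within the scatter both times, but it does not show that a real effect of the change carries from one core to the other, as neither step can be told apart from repeat-measurement noise, nor does it show that the two groups would be interchangeable on other cores or in other assays.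

The compounds shown leave open whether this ring needs its substituents at all, and whether a plain phenyl ring, or a methoxy group or nitrile in place of the chlorine or trifluoromethyl, would move the number beyond the scatter. They also leave open what would happen if the phenylethyl group at the end of the amide arm gave way to a simple amine or a carboxylic acid.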